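The source may hold more compounds than are shown below. What is called first, only, known or untested is meant among the compounds shown, and "the series" means these compounds.

Compounds measured:
compound 1 `COC(=O)[C@@]1(C)CCC=C2[C@@H]1CC[C@@H](C)[C@]2(C)Cc1c(C)[nH]c2ccc(Br)cc12` with 15000 nM in a functional assay on A549 cells (Homo sapiens) for inhibition, read by sulforhodamine B assay, with a stated time of 48 h; a higher number here means a weaker inhibitor of growth, a lower number a stronger inhibitor of growth;
compound 2 `COC(=O)[C@@]1(C)CCC=C2[C@@H]1CC[C@@H](C)[C@]2(C)Cc1c(C)[nH]c2ccc(F)cc12` with 15000 nM;
compound 3 `COC(=O)[C@@]1(C)CC[C@@H]2C3=C1CC[C@@H](C)[C@]3(C)Cc1c2[nH]c2ccccc12` with 4600 nM.

Compound 3 gives the lowest of the three numbers, and its separation from compound 1 and from compound 2 lies beyond the scatter. Compound 4 `COC(=O)[C@@]1(C)CC[C@@H]2C3=C1CC[C@@H](C)[C@]3(C)Cc1c2[nH]c2ccc(C)cc12` differs from compound 3 by methyl in place of hydrogen on an aromatic carbon. Within the data shown here, the only measured step that touches the same aromatic ring is no change at the digits printed from compound 1 to compound 2 (within the scatter), a change at one aromatic carbon that left the growth inhibition unmoved. From that single step, a substituent swap on this ring is expected to matter little, so compound 4 is expected to show a step of no change at the digits printed from compound 3 to compound 4 (within the scatter), none beyond the scatter. Compound 4 is therefore estimated at 4600 nM, with a range from 2000 nM to 11000 nM.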

Compound 4, concentration for 50% growth inhibition: 16000 nM
For compound 4 the middle estimate is 3.5-fold (0.54 log units) below the measured one; measured number outside the range, above it.
By their numbers in this assay, from the lowest: compound 3; then compounds 1, 2 and 4 (each within the scatter of the next).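

On the core of compound 3, methyl in place of hydrogen on this aromatic carbon gives a 3.5-fold higher number from compound 3 to compound 4 (0.54 log units; beyond the scatter) in this assay. A single added carbon on this ring, meta to a fused ring and para to a fused ring, is thus enough to weaken growth inhibition, whereas the fluoro for bromo swap on the other core gave no change at the digits printed from compound 1 to compound 2 (within the scatter) and suggested no such sensitivity. Nothing available explains this step.

Going by these compounds, whether a methoxy group, an amine or a carboxylic acid at this carbon would behave like methyl remains open. So does whether fluoro or bromo on the core of compound 3 would match hydrogen or methyl.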